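From 3,4-dichlorophenyl to 4-methylphenyl on the sulfonyl sulfur

This account rests on a few compounds, and the source may have more. Where it says the series, first, only, none or still open, it means among the compounds named here.

Three compounds sharing one core have gone into a functional assay on HCT-116 cells (Homo sapiens) for cytotoxicity; a higher number here means that more compound is needed for the effect, a lower number that less compound is needed: compound 1 (`CC(=O)SCC(=O)c1ccc(NS(=O)(=O)c2ccc(OC(F)(F)F)cc2)cc1`), compound 2 (`CC(=O)SCC(=O)c1ccc(NS(=O)(=O)c2ccc(Cl)c(Cl)c2)cc1`) and compound 3 (`CC(=O)SCC(=O)c1ccc(NS(=O)(=O)c2cccc(OC(F)(F)F)c2)cc1`). Within the data shown here, only one has yielded a number so far: in this assay compound 1 gives 8800 nM. Compound 2 is recorded as "not determined" (no result reported), so it has no place on the scale next to that single value. Compound 3 is recorded as "not determined" (no result reported).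

The next structure is compound 4 (`CC(=O)SCC(=O)c1ccc(NS(=O)(=O)c2ccc(C)cc2)cc1`). The change is 4-methylphenyl in place of 3,4-dichlorophenyl on a sulfonyl sulfur, with 4-methylphenyl in place of 3,4-dichlorophenyl on a sulfonyl sulfur. This step has no measured starting point, since compound 2 carries no number. Among the measured compounds shown here, no step beyond the scatter is expected in this assay, in either direction, and the only anchor is compound 1 at 8800 nM. For compound 4 the expected half-maximal effective concentration is 10000 nM, with an estimated range of 3500 nM to 30000 nM.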

Compound 4, half-maximal effective concentration: 6500 nM
The estimate for compound 4 lay 1.5-fold (0.19 log units) above the measured number; low and high end bracket the measured number.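

In this assay the series now has its first readable step, which is a 1.4-fold lower number from compound 1 to compound 4 (0.13 log units; within the scatter) for methyl in place of trifluoromethoxy on an aromatic carbon, so these two groups are not told apart on the aromatic ring carried by the sulfonyl sulfur. The steps from compound 2 and compound 3 cannot be read, as neither compound has a number, so the exchange of 3,4-dichlorophenyl for 4-methylphenyl remains unresolved. Nothing measured here bears on the reason for this result.

Still open, going by these compounds, is whether any group on this ring separates from the scatter at all, for instance an amine, a carboxylic acid or a longer alkyl chain in place of methyl. The compounds shown also leave open whether the thioacetate end of the shared core matters to the number, since it is the same in all of them.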